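Swapping the sulfonamide for a benzyl sulfone

The compounds below may be only part of what the source reports. "The series", "measured", "known", "first", "only" and "open" are said of these compounds alone.

Measured compounds:
compound 2, `COCCN(C)S(=O)(=O)c1ccc(C)c(C#Cc2cc(Cl)ccc2OCC(=O)O)c1`: 4.1 nM
compound 1, `O=C(O)COc1ccc(Cl)cc1C#Cc1ccncc1`: 601 nM

Of the compounds shown here, two have been tested in an assay on CHO cells for displacement of a labelled ligand from prostaglandin D2 receptor 2 (Homo sapiens), read by scintillation counting; a higher number here means a weaker inhibitor, a lower number a stronger inhibitor. Compound 2 gives 4.1 nM, the lowest of the two numbers, and compound 1 gives 601 nM; the gap between them lies well beyond the usual scatter of this assay, so compound 2 is clearly the stronger binder of the pair. Among the measured compounds shown here, no single-point step between the two is on record, since they differ in more than one place.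

Compound 3, `Cc1ccc(S(=O)(=O)Cc2ccccc2)cc1C#Cc1cc(Cl)ccc1OCC(=O)O`, is the next compound to be measured. It is built from compound 2 by one change: benzyl in place of (2-methoxyethyl)(methyl)amino on a sulfonyl sulfur. The sulfonyl group itself stays; what changes is the group attached to it.

For the measured compounds named here, no measured step of this kind exists here, so the expectation rests on compound 2 alone. Compound 3 is expected to remain close to compound 2, with at most a modest step, a 2.9-fold higher number from compound 2 to compound 3 (0.47 log units; beyond the scatter), likely toward a somewhat higher number. The estimate for compound 3 in this assay is 12 nM, with a range from 2.5 nM to 60 nM.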

Compound 3, inhibition constant: 5 nM
For compound 3 the middle estimate is 2.4-fold (0.38 log units) above the measured one; measured number inside the range.
By their numbers in this assay, from the lowest: compounds 2 and 3 (each within the scatter of the next); then compound 1.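

In this assay, the exchange gives a 1.2-fold higher number from compound 2 to compound 3 (0.09 log units; within the scatter), so compound 2 and compound 3 cannot be told apart in their binding. What this adds is that, on a sulfonyl sulfur whose other neighbour is an aromatic carbon, two quite different groups give matching numbers: the ringless (2-methoxyethyl)(methyl)amino, with its nitrogen and one hydrogen-bond acceptor, and the all-carbon benzyl, with its six-membered aromatic ring and no hydrogen-bond acceptor. Nothing at hand explains why these two groups match, so the result remains an observation about this one pair of compounds.

The compounds shown leave open whether a much smaller group on the sulfonyl sulfur, such as a single methyl, or a charged group, such as an amine or a carboxylic acid carried on the benzyl ring, would fit this pattern. They also leave open whether the sulfonyl itself matters, which a carbonyl in its place could test, since compound 1 differs from compound 2 and compound 3 in more than one place and cannot settle that question.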